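From a Urea to a Semicarbazide on the Shared Core

The compounds below may be only part of what the source reports. "The series", "measured", "known", "first", "only" and "open" are said of these compounds alone.

Of the compounds shown here, three built on one core have been measured in a functional assay on CCRF-CEM cells (Homo sapiens) for inhibition, read by MTT assay, with a stated time of 72 h; on this read-out lower numbers stand for stronger inhibition and higher numbers for weaker inhibition. Compound 1 `COc1cc(NC(C)CCCNC(=O)NNC(=O)Nc2cccc(F)c2)c2ncccc2c1` gives 98000 nM in this assay. Compound 2 `COc1cc(NC(C)CCCNC(=O)NNC(=O)Nc2cc(C(F)(F)F)cc(C(F)(F)F)c2)c2ncccc2c1` gives 13000 nM, and compound 3 `COc1cc(NC(C)CCCNC(=O)Nc2ccc(C(F)(F)F)cc2)c2ncccc2c1` gives 14000 nM. Going by the values given here, compound 3 therefore stands second highest of the three numbers; its nearest neighbour is compound 2, within the scatter, while compound 1 lies furthest away, with the step of a 7.0-fold lower number from compound 1 to compound 3 (0.85 log units; beyond the scatter) being the only single-point change measured so far.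

Compound 4 `COc1cc(NC(C)CCCNC(=O)NNC(=O)Nc2cccc(Cl)c2)c2ncccc2c1` has not yet been measured. It differs from compound 3 as follows: ((3-chlorophenyl)carbamoyl)amino in place of 4-(trifluoromethyl)phenyl on an amide-type nitrogen. Among the compounds with values here, this change largely reverses the one measured step, since compound 1 also carries a ((3-halophenyl)carbamoyl)amino group on that nitrogen, differing from compound 4 only in the halogen. The step from compound 1 to compound 3 was modest but beyond the scatter and ran toward lower numbers; the return is therefore expected to run toward higher numbers in this assay, though compound 2, with a semicarbazide of its own, shows that such a group need not give a weak number.

Compound 4 is accordingly expected to give 45000 nM, with a range of 15000 nM to 140000 nM, which corresponds to an estimated step of a 3.2-fold higher number from compound 3 to compound 4 (0.51 log units; beyond the scatter).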

Compound 4, half-maximal inhibitory concentration: 81000 nM
Estimate against measurement, compound 4: 1.8-fold (0.26 log units) below, within the range that was stated.
By their numbers in this assay, from the lowest: compounds 2 and 3 (each within the scatter of the next); then compounds 4 and 1 (each within the scatter of the next).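

In this assay the exchange on the amide-type nitrogen now reads in both directions: a 5.8-fold higher number from compound 3 to compound 4 (0.76 log units; beyond the scatter) runs opposite to a 7.0-fold lower number from compound 1 to compound 3 (0.85 log units; beyond the scatter) and shows that the higher number returns with a second halogen on the ((3-halophenyl)carbamoyl)amino group. The halogen itself makes no readable difference in this pair, as chloro in place of fluoro on an aromatic carbon gives a 1.2-fold lower number from compound 1 to compound 4 (0.08 log units; within the scatter) and so stays within the scatter, although compound 2 goes against any rule that this kind of group always brings a high number. Nothing measured on these compounds accounts for either step.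

The step to compound 4 replaces the whole 4-(trifluoromethyl)phenyl with the larger ((3-chlorophenyl)carbamoyl)amino group, so these compounds leave open how much of it belongs to the added carbonyl and nitrogens and how much to the change on the aromatic ring. They also leave open whether a nitrile or a methoxy group in place of the halogen would keep the number where chloro and fluoro leave it, and whether a longer chain to the shared core would alter the picture.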